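Moving the Hydroxyl Around a Furan-Bearing Core

The compounds below may be only part of what the source reports. "The series", "measured", "known", "first", "only" and "open" are said of these compounds alone.

In a functional assay on T47D cells (Homo sapiens) for cytotoxicity, read by CCK-8 assay (a lower number here means a stronger inhibitor, a higher number a weaker inhibitor), compound 3 `Oc1cccc(-c2cc(-c3ccco3)cc(-c3ccccc3O)n2)c1` gives 820 nM. Of the two plain numbers shown it is the higher one, but its nearest neighbour, compound 1 `Oc1ccc(-c2cc(-c3ccsc3)cc(-c3cccc(O)c3)n2)cc1`, gives 760 nM, and that gap lies within the scatter, so the two cannot be ranked against each other. Compound 2 `Oc1ccccc1-c1cc(-c2ccco2)cc(-c2ccccc2O)n1` gives > 50000 nM, which is a limit of the assay rather than a number, (the limit of > 50000 nM in this assay, at which 1 of the 3 values shown sits).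

Within the data shown here, the one measured step that bears on the question is the change from compound 2 to compound 3, where 3-hydroxyphenyl took the place of 2-hydroxyphenyl and the number fell sharply, an at least 60-fold lower number from compound 2 to compound 3 (1.78 log units; beyond the scatter). Compound 4 `Oc1ccc(-c2cc(-c3ccco3)cc(-c3cccc(O)c3)n2)cc1` differs from compound 3 by the remaining such swap: 4-hydroxyphenyl in place of 2-hydroxyphenyl on an aromatic carbon. Compound 1 already carries a 4-hydroxyphenyl together with a 3-hydroxyphenyl on a core that bears a thiophene instead of a furan, and its number sits close to that of compound 3.

Taken together, the earlier step and the value of compound 1 suggest that compound 4 is expected to stay close to compound 3, with at most a small drop, a 1.4-fold lower number from compound 3 to compound 4 (0.14 log units; within the scatter). The estimate for compound 4 is 600 nM, expected to fall between 200 nM and 2000 nM.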

Compound 4, half-maximal inhibitory concentration: 1280 nM
Compound 4: the middle estimate sits 2.1-fold (0.33 log units) below what was measured; the measured number falls inside the stated range.
By their numbers in this assay, from the lowest: compounds 1, 3 and 4 (each within the scatter of the next). At a limit, above all of these: compound 2.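

The new swap shows that, with a 3-hydroxyphenyl group on the other side of the shared core, the hydroxyl of the group next to the ring nitrogen can move without a readable effect in this assay: replacing 2-hydroxyphenyl with 4-hydroxyphenyl gives a 1.6-fold higher number from compound 3 to compound 4 (0.19 log units; within the scatter). The other new comparison tells the same kind of story for a different place, since furan-2-yl in place of thiophen-3-yl gives a 1.7-fold higher number from compound 1 to compound 4 (0.23 log units; within the scatter), so this pair does not separate the two rings. Compound 2, which carries two 2-hydroxyphenyl groups, remains the exception to this tolerance, and its value is a limit of the assay and not a number: the limit of > 50000 nM in this assay, at which 1 of the 4 values shown sits.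

Every group shown at the place next to the ring nitrogen is a hydroxyphenyl, so it remains open whether the hydroxyl matters there at all, or whether a plain phenyl, a methoxyphenyl, an aminophenyl or a ring bearing a carboxylic acid would fare the same. Going by these compounds, it is also open whether the tolerance seen here holds with thiophen-3-yl in place of furan-2-yl, since 2-hydroxyphenyl appears in these compounds only alongside a furan-2-yl group.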